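Aryl substituent swap at the shared core

A few compounds are considered here, and "the series" means these few. Any claim that something is new, unique, unknown or untested is made for them only; others in the source may bear on it.

Measured so far in a functional assay on HeLa cells (Homo sapiens) for inhibition, read by CCK-8 assay, with a stated time of 48 h; on this read-out higher numbers stand for weaker inhibition and lower numbers for stronger inhibition:
compound 1 `COc1ccc(C2=NN(C3=NC(c4ccccc4)CS3)C(c3cccc4ccccc34)C2)cc1`: 3310 nM
compound 2 `Fc1ccc(C2=NN(C3=NC(c4ccccc4)CS3)C(c3cccc4ccccc34)C2)cc1`: 12400 nM

Compound 2 stands highest of the two numbers, with compound 1 the nearest and lower. Among the measured compounds shown here, the one measured step is a 3.7-fold higher number from compound 1 to compound 2 (0.57 log units; beyond the scatter). Compound 3 `Cc1ccc(C2=NN(C3=NC(c4ccccc4)CS3)C(c3cccc4ccccc34)C2)cc1C` differs from compound 2 by 3,4-dimethylphenyl in place of 4-fluorophenyl on a carbon with a double bond to nitrogen. For the measured compounds named here, no measured step covers this exact change; the step from compound 1 to compound 2 touches the same aryl carbon and shows that exchanging the fluoro can move the number beyond the scatter. A modest fall is therefore expected in this assay, a 2.5-fold lower number from compound 2 to compound 3 (0.39 log units; beyond the scatter). Compound 3 is estimated at 5000 nM, range 1500 nM to 16000 nM.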

Compound 3, half-maximal inhibitory concentration: 1720 nM
Compound 3: the middle estimate sits 2.9-fold (0.46 log units) above what was measured; the range from low to high includes it.
By their numbers in this assay, from the lowest: compounds 3 and 1 (each within the scatter of the next); then compound 2.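

In this assay, 3,4-dimethylphenyl in place of 4-fluorophenyl on this carbon gives a 7.2-fold lower number from compound 2 to compound 3 (0.86 log units; beyond the scatter). In place of 4-methoxyphenyl the same group gives a 1.9-fold lower number from compound 1 to compound 3 (0.28 log units; within the scatter), so of the three aryl groups only 4-fluorophenyl stands apart from the other two. No measured evidence accounts for this result.

Going by these compounds, whether a phenyl ring carrying an amine or a carboxylic acid stays level with compound 1 and compound 3 remains open. Also open, on these data alone, is whether a single methyl group would match 3,4-dimethylphenyl.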